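Chalcone-bearing fused cores against DU-145 cells

This account rests on a few compounds, and the source may have more. Where it says the series, first, only, none or still open, it means among the compounds named here.

Compound 1 `COc1ccc(-c2cc(C(=O)/C=C/c3cc(OC)c(OC)c(OC)c3)nc3cc(-c4ccccc4)nn23)cc1OC`: 14700 nM
Compound 2 `COc1ccc(-c2cc(/C=C/C(=O)c3ccccc3)nc3cc(-c4ccccc4)nn23)cc1OC`: 10000 nM

Two compounds share a core and differ in the chalcone-type side chain. In a functional assay on DU-145 cells (Homo sapiens) for antiproliferative activity, read by MTT assay, with a stated time of 24 h (on this read-out higher numbers stand for weaker inhibition and lower numbers for stronger inhibition), compound 1 gives 14700 nM, and compound 2 gives 10000 nM. Compound 2 has the lowest of the two numbers, but compound 1 sits within the scatter of it, so the two values show no difference worth reading.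

Compound 3 `COc1ccc(-c2cc(C(=O)/C=C/c3ccc(Cl)cc3)nc3cc(-c4ccccc4)nn23)cc1OC` is not yet measured. It differs from compound 2 in one place: (2-(4-chlorophenyl)ethenyl)carbonyl in place of 2-benzoylethenyl on an aromatic carbon. The incoming group carries a chlorine on its six-membered aromatic ring of carbon only, and it resembles the side chain of compound 1 more than that of compound 2. Because compound 1 gives 14700 nM and compound 2 gives 10000 nM in this assay, no step beyond the scatter is expected from compound 2 to compound 3; the expected step is a 1.2-fold higher number from compound 2 to compound 3 (0.08 log units; within the scatter). Compound 3 is estimated at 12000 nM, with a range from 4000 nM to 36000 nM.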

Compound 3, half-maximal inhibitory concentration: 22400 nM
Estimate against measurement, compound 3: 1.9-fold (0.27 log units) below; the range from low to high includes it.
By their numbers in this assay, from the lowest: compounds 2, 1 and 3 (each within the scatter of the next, the first and the last beyond it).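

In this assay, for the compounds shown here, (2-(4-chlorophenyl)ethenyl)carbonyl in place of 2-benzoylethenyl on this aromatic carbon gives a 2.2-fold higher number from compound 2 to compound 3 (0.35 log units; beyond the scatter) and is the first step here beyond the scatter, though a modest one. By contrast, 4-chlorophenyl in place of 3,4,5-trimethoxyphenyl on the double-bonded chain carbon gives a 1.5-fold higher number from compound 1 to compound 3 (0.18 log units; within the scatter) and so cannot be told from repeat scatter. The larger step therefore belongs to the side-chain exchange as a whole, which both places the carbonyl on the aromatic carbon and adds a chlorine, and these compounds do not separate the two.

Nothing shown accounts for either step. Still open, from the compounds shown here alone, is how 2-benzoylethenyl carrying a chlorine on its ring would read at this position, and how a side chain ending in an amine or a carboxylic acid would compare.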